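From compound 3 to compound 4: changing the amino side chain

The compounds below may be only part of what the source reports. "The series", "measured", "known", "first", "only" and "open" are said of these compounds alone.

In a functional assay on G-361 cells (Homo sapiens) for cytotoxicity, read by fluorescence, with a stated time of 72 h (a lower number here means a stronger inhibitor, a higher number a weaker inhibitor), compound 1 (`CC(C)c1n[nH]c2c(NCc3ccc(-c4ccccn4)cc3)nc(NCCO)nc12`) gives 39 nM and compound 2 (`CC(C)c1n[nH]c2c(NCc3ccc(-c4ccccn4)cc3)nc(NCC(C)(C)O)nc12`) gives 48 nM. Compound 3 (`CC(C)c1n[nH]c2c(NCc3ccc(-c4ccccn4)cc3)nc(N3CCCCC3CCO)nc12`) has the highest number of the three, at 204 nM. Compound 4 (`CC(C)c1n[nH]c2c(NCc3ccc(-c4ccccn4)cc3)nc(N[C@@H]3CCCC[C@H]3N)nc12`) carries (2-aminocyclohexyl)amino in place of the 2-(2-hydroxyethyl)piperidin-1-yl of compound 3 on an aromatic carbon ((2-aminocyclohexyl)amino in place of 2-(2-hydroxyethyl)piperidin-1-yl on an aromatic carbon). Two modest steps bear on this change: a 5.2-fold higher number from compound 1 to compound 3 (0.72 log units; beyond the scatter) and a 4.3-fold higher number from compound 2 to compound 3 (0.63 log units; beyond the scatter). The step of a 1.2-fold higher number from compound 1 to compound 2 (0.09 log units; within the scatter) lies within the scatter. Among the measured compounds shown here, compound 4 regains the amino link of compound 1 and compound 2, so a reversal of similar size is expected, although no measured compound carries its ring. The estimated step is a 6.8-fold lower number from compound 3 to compound 4 (0.83 log units; beyond the scatter). Compound 4 is estimated at 30 nM, within a range of 10 nM to 90 nM.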

Compound 4, half-maximal inhibitory concentration: 477 nM
For compound 4 the middle estimate is 16-fold (1.20 log units) below the measured one; the whole stated range lies below it.
By their numbers in this assay, from the lowest: compounds 1 and 2 (each within the scatter of the next); then compound 3; then compound 4.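

In this assay, the return of an amino link at this aromatic carbon did not bring the number back down, giving a 2.3-fold higher number from compound 3 to compound 4 (0.37 log units; beyond the scatter), so that link alone does not set the value. On the same nitrogen, 2-aminocyclohexyl gave a 9.9-fold higher number from compound 2 to compound 4 (1.00 log units; beyond the scatter) and a 12-fold higher number from compound 1 to compound 4 (1.09 log units; beyond the scatter), the largest steps seen at this position. No measurement offered here explains this result. As far as these compounds go, whether the loss follows the cyclohexane ring or its amine remains open, and 2-hydroxycyclohexyl or plain cyclohexyl on that nitrogen would separate the two. From the compounds shown here alone, the effect of the two defined stereocentres also remains open.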